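Urea series: replacing 3-nitrophenyl on compound 2

The source may report more compounds than this note shows. Statements on the series, on what has been measured and on what is new or still open speak of the compounds shown alone.

- compound 1 `O=C(Nc1ccccc1)Nc1nc(-c2cc3cc([N+](=O)[O-])ccc3o2)cs1` gives 183000 nM
- compound 2 `O=C(Nc1cccc([N+](=O)[O-])c1)Nc1nc(-c2cc3cc(Br)ccc3o2)cs1` gives 159000 nM
- compound 3 `O=C(Nc1nc(-c2cc3ccccc3o2)cs1)Nc1ccccc1[N+](=O)[O-]` gives 20300 nM

In a physicochemical assay, with a stated time of 6 min (a lower number here means a stronger inhibitor, a higher number a weaker inhibitor), compound 2 stands at 159000 nM and is level with compound 1 within the scatter. Compound 3 has a clearly lower number than compound 2, a gap beyond the scatter.

The next compound to be measured is compound 4 `O=C(Nc1ccc(F)cc1)Nc1nc(-c2cc3cc(Br)ccc3o2)cs1` and the change is 4-fluorophenyl in place of 3-nitrophenyl on an amide-type nitrogen with 4-fluorophenyl in place of 3-nitrophenyl on an amide-type nitrogen. For the measured compounds named here, no measured pair differs in one place only, so the size of this step cannot be read directly. Compound 1 at 183000 nM and compound 2 at 159000 nM differ in more than one place and still lie within the scatter of each other. On that basis, no step beyond the scatter is expected in this assay in either direction. The estimated step of a 1.2-fold lower number from compound 2 to compound 4 (0.09 log units; within the scatter) is small for that reason. Compound 4 is estimated at 130000 nM (expected range 40000 nM to 300000 nM).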

Compound 4, half-maximal inhibitory concentration: > 200000 nM
Compound 4 ended at the assay's limit; the forecaster's own chance of this, stated with the estimate: 15%; middle value at least 1.5-fold (0.18 log units) from the limit.
By their numbers in this assay, from the lowest: compound 3; then compounds 2 and 1 (each within the scatter of the next). At a limit, above all of these: compound 4.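

In this assay compound 4 reads > 200000 nM, which is a limit of the assay and not a number. Placing 4-fluorophenyl in place of 3-nitrophenyl on the amide-type nitrogen gives an at least 1.2-fold higher number from compound 2 to compound 4 (0.09 log units; that floor lies within the scatter), the only one-place step among the compounds shown, and it shows no shift towards a lower number at this position, though it does not establish a real rise either. The true size of this step stays unread, and only one compound of the series has reached this ceiling so far: the limit of > 200000 nM in this assay, at which 1 of the 4 values shown sits.

Steps involving compound 1 or compound 3 cannot be read, since each differs from the other compounds in more than one place. Still open, from the compounds shown here alone, is whether any group on this nitrogen, such as an aryl group carrying an amine or a carboxylic acid, or a longer chain, moves the number beyond the scatter on the core of compound 2.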